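This account rests on a few compounds, and the source may have more. Where it says the series, first, only, none or still open, it means among the compounds named here.

In an ADME assay on microsomes from liver (Mus musculus, strain CD-1) for metabolic stability, read by LC-MS, tested at 2 uM (on this read-out lower numbers stand for a shorter-lived compound and higher numbers for a longer-lived compound), compound 1 `Cn1ccc2ccc(-c3cc(Nc4ccccc4S(N)(=O)=O)cc4nccnc34)cc21`, with an amino group on its sulfonyl sulfur, gives 0.5 h. Compound 2 `CN(Cc1cncnc1)S(=O)(=O)c1ccccc1Nc1cc(-c2ccc3ccn(C)c3c2)c2nccnc2c1` gives 0.2 h, the lower of the two numbers. Within the data shown here, the one measured step, a 2.5-fold lower number from compound 1 to compound 2 (0.40 log units; beyond the scatter), is modest but beyond the usual scatter, and it comes with methyl((pyrimidin-5-yl)methyl)amino in place of amino on a sulfonyl sulfur.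

Compound 3 `Cn1cc(CNS(=O)(=O)c2ccccc2Nc2cc(-c3ccc4ccn(C)c4c3)c3nccnc3c2)cn1` shares its core with compound 2 and differs at that same place: ((1-methyl-1H-pyrazol-4-yl)methyl)amino in place of methyl((pyrimidin-5-yl)methyl)amino on a sulfonyl sulfur. A five-membered aromatic ring thus takes the place of a six-membered one. Among the measured compounds shown here, no measured step covers this exchange directly. The nearest guide, a 2.5-fold lower number from compound 1 to compound 2 (0.40 log units; beyond the scatter), starts from a bare amino group, whereas here one ring-bearing group replaces another, so it says little about the size of this change. Compound 2, at 0.2 h, therefore remains the best anchor.

The estimated step is no change at the digits printed from compound 2 to compound 3 (within the scatter), so no change beyond the scatter is expected in this assay. Compound 3 is expected at about 0.2 h, with an estimated range from 0.1 h to 0.5 h.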

Compound 3, half-life in the Mus musculus assay: 0.267 h
For compound 3 the middle estimate is 1.3-fold (0.13 log units) below the measured one, within the range that was stated.
By their numbers in the Mus musculus assay, from the lowest: compounds 2, 3 and 1 (each within the scatter of the next, the first and the last beyond it).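

In the Mus musculus assay compound 2 gives 0.2 h and compound 3 gives 0.267 h and the exchange on the sulfonyl sulfur gives a 1.3-fold higher number from compound 2 to compound 3 (0.13 log units; within the scatter) and so leaves the two ring-bearing groups indistinguishable, even though one carries a six-membered aromatic ring and the other a five-membered one, and only the entering group has a hydrogen-bond donor. Compound 3 also adds a new comparison with the bare sulfonamide: in the Mus musculus assay there is a 1.9-fold lower number from compound 1 to compound 3 (0.27 log units; within the scatter) for this group, whereas the earlier step showed a 2.5-fold lower number from compound 1 to compound 2 (0.40 log units; beyond the scatter) and so lay beyond the scatter. In a physicochemical assay for solubility, read by spectrophotometry, measured as kinetic solubility, at pH 8, tested at 500 uM (a higher number here means a more soluble compound, a lower number a less soluble compound), compound 2 gives 3 ug/mL and compound 3 gives 2 ug/mL and the same exchange gives a 1.5-fold lower number from compound 2 to compound 3 (0.18 log units; within the scatter) and so does not separate the two groups on solubility either.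

The exchange changes the ring and removes the methyl on the sulfonamide nitrogen together, so the compounds shown cannot separate those two parts, and a methyl((1-methyl-1H-pyrazol-4-yl)methyl)amino group or a carboxylic acid on the side chain would be needed to extend the comparison. Nothing shown here offers an explanation for how these groups read in either assay.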